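The source may report more compounds than this note shows. Statements on the series, on what has been measured and on what is new or still open speak of the compounds shown alone.

Compound 1 `CN(C)CCn1cnnc1-c1cc(Oc2ccc(NC(=O)N/N=C/c3cccc(O)c3)cc2F)ccn1` gives 1370 nM in a functional assay on MKN-45 cells (Homo sapiens) for cytotoxicity, read by MTT assay, with a stated time of 72 h; a lower number here means a stronger inhibitor, a higher number a weaker inhibitor.
Compound 2 `CN(C)CCn1cnnc1-c1cc(Oc2ccc(NC(=O)N/N=C/c3c[nH]c4ccccc34)cc2F)ccn1` gives 790 nM in this assay.
Compound 3 `Cc1cc(/C=N/NC(=O)Nc2ccc(Oc3ccnc(-c4nncn4CCN(C)C)c3)c(F)c2)cc(C)c1O` gives 1510 nM in this assay.

All three compounds share the same core and differ only in the aromatic group attached to the carbon that carries a double bond to nitrogen. Their three numbers all lie within the usual scatter of one another, so none of them can be set apart; the steps of a 1.1-fold higher number from compound 1 to compound 3 (0.04 log units; within the scatter) and a 1.9-fold higher number from compound 2 to compound 3 (0.28 log units; within the scatter) show how little compound 3 is separated from the other two in this assay.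

Compound 4 `CN(C)CCn1cnnc1-c1cc(Oc2ccc(NC(=O)N/N=C/c3ccc(F)cc3F)cc2F)ccn1` continues this series: 2,4-difluorophenyl in place of 4-hydroxy-3,5-dimethylphenyl on a carbon with a double bond to nitrogen. The steps measured so far all exchange the aromatic group at this same carbon, and each was within the scatter: a 1.7-fold lower number from compound 1 to compound 2 (0.24 log units; within the scatter), a 1.1-fold higher number from compound 1 to compound 3 (0.04 log units; within the scatter) and a 1.9-fold higher number from compound 2 to compound 3 (0.28 log units; within the scatter). For the measured compounds named here, none of the measured groups is free of hydrogen-bond donors and acceptors, so nothing on record speaks to that part of the change. On the evidence of these three steps, the expectation for compound 4 is a step of a 1.2-fold lower number from compound 3 to compound 4 (0.07 log units; within the scatter), that is, no movement beyond the scatter. Compound 4 is therefore estimated at 1300 nM in this assay, with a range from 500 nM to 3500 nM.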

Compound 4, half-maximal inhibitory concentration: 810 nM
Beside the measured number, compound 4's estimate is 1.6-fold (0.21 log units) above it; the range from low to high includes it.
By their numbers in this assay, from the lowest: compounds 2, 4, 1 and 3 (each within the scatter of the next).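

For the compounds shown here, compound 4 is the only one of the four compounds whose group at this carbon, 2,4-difluorophenyl, has 0 hydrogen-bond donors and 0 hydrogen-bond acceptors, yet in this assay its number stays within the scatter of all three others: against 4-hydroxy-3,5-dimethylphenyl (a 1.9-fold lower number from compound 3 to compound 4 (0.27 log units; within the scatter)), against 1H-indol-3-yl (a 1.0-fold higher number from compound 2 to compound 4 (0.01 log units; within the scatter)) and against 3-hydroxyphenyl (a 1.7-fold lower number from compound 1 to compound 4 (0.23 log units; within the scatter)). Among these four compounds, then, an aromatic group with fluorine and no hydroxyl or ring hydrogen on nitrogen cannot be told apart from the groups that carry them, so the hydrogen-bond donors and acceptors of the group at this carbon show no effect that rises above the scatter in this read-out. Nothing on record explains this flat result, which stands as a plain observation.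

All four groups shown are aromatic rings, so what a simple amine, a carboxylic acid or a longer alkyl chain would do on this carbon stays open. On these data alone, the four compounds also share one core and are compared here only in this assay so whether these groups would separate on another core or in another test remains unknown.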